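The compounds below may be only part of what the source reports. "The series", "measured", "known", "first", "only" and "open" are said of these compounds alone.

In a functional assay on CHO cells for agonist activity at Alpha-1D adrenergic receptor (Homo sapiens), read by FLIPR and calcium flux (a higher number here means that more compound is needed for the effect, a lower number that less compound is needed), compound 2 `c1cc(-c2ccn[nH]2)c2c(c1)C(c1ncc[nH]1)CC2` gives 336 nM, the only plain number among the two results shown. Compound 1 `CCCS(=O)(=O)Nc1cccc2c1CCC2c1ncc[nH]1` gives > 10000 nM in this assay, which is a limit of the assay rather than a measured number (the limit of > 10000 nM in this assay, at which 1 of the 2 values shown sits). Within the data shown here, the one measured comparison is an at least 29-fold lower number from compound 1 to compound 2 (1.47 log units; beyond the scatter), a large step that shows how strongly the group on this aromatic carbon can shift the result. Compound 3 `COc1cccc2c1CCC2c1ncc[nH]1` differs from compound 2 by methoxy in place of 1H-pyrazol-5-yl on an aromatic carbon. Methoxy is smaller than either group in the measured pair and, unlike 1H-pyrazol-5-yl, carries no hydrogen-bond donor, so the measured step is only an indirect guide. Compound 3 is therefore expected to need more compound than compound 2, an estimated step of a 7.4-fold higher number from compound 2 to compound 3 (0.87 log units; beyond the scatter) in this assay. The estimate for compound 3 is 2500 nM, with a range from 400 nM to 10000 nM.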

Compound 3, half-maximal effective concentration: > 10000 nM
Compound 3: only a limit was reported; the forecaster's own chance of this, stated with the estimate: 30%; middle value at least 4.0-fold (0.60 log units) from the limit.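

Methoxy in place of 1H-pyrazol-5-yl brings an at least 29-fold higher number from compound 2 to compound 3 (1.47 log units; beyond the scatter) in this assay, so the effect seen with compound 2 does not survive this swap to a smaller group with no ring. Compound 1 no longer stands alone, since two quite different groups on this aromatic carbon, (propylsulfonyl)amino and methoxy, now give no plain number, and 1H-pyrazol-5-yl is the only one that does. Compound 3 gives a limit, not a number, and it sits with compound 1 at the same limit, so the step between those two cannot be read: the limit of > 10000 nM in this assay, at which 2 of the 3 values shown sit.

The change from compound 2 to compound 3 removes both the ring and the hydrogen-bond donor, so the compounds shown cannot say which of the two matters. A phenyl ring or a simple amine on this carbon would begin to separate them.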